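The compounds below may be only part of what the source reports. "The series", "measured", "known", "first", "only" and "open" are said of these compounds alone.

Measured compounds:
- Compound 1 `O=C(CSc1nnnn1-c1cccc2ccccc12)N/N=C/c1cccc(Cl)c1`; in an ADME assay on MT4 cells (Homo sapiens) for cytotoxicity, read by MTT assay (a lower number here means that less compound is tolerated, a higher number that more compound is tolerated), compound 1 gives 240000 nM
- Compound 2 `COc1cccc(/C=N/NC(=O)CSc2nnnn2-c2cccc3ccccc23)c1OC`; in this assay compound 2 gives 192000 nM

Among the measured compounds shown here, compound 2 stands at the lower of the two numbers measured so far, but its nearest neighbour is compound 1, and the step of a 1.3-fold lower number from compound 1 to compound 2 (0.10 log units; within the scatter) stays within the scatter, so the two compounds are not distinguished by this assay. Compound 3 `COc1ccc(O)c(/C=N/NC(=O)CSc2nnnn2-c2cccc3ccccc23)c1` keeps the shared core and differs from compound 2 only in 2-hydroxy-5-methoxyphenyl in place of 2,3-dimethoxyphenyl on a carbon with a double bond to nitrogen. For the measured compounds named here, one measured step bears on this change: the swap of the aryl group on the same carbon from compound 1 to compound 2, which moved the number by a 1.3-fold lower number from compound 1 to compound 2 (0.10 log units; within the scatter), within the scatter. A second aryl swap at that place is therefore expected to move the number little, and the expected step of a 1.0-fold lower number from compound 2 to compound 3 (0.00 log units; within the scatter) lies within the scatter. For compound 3 the estimate in this assay is 190000 nM, with a range from 90000 nM to 400000 nM.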

Compound 3, half-maximal cytotoxic concentration: 4510 nM
Beside the measured number, compound 3's estimate is 42-fold (1.62 log units) above it; measured number outside the range, below it.
By their numbers in this assay, from the lowest: compound 3; then compounds 2 and 1 (each within the scatter of the next).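

In this assay, the aryl group on the carbon with a double bond to nitrogen now proves able to change the number strongly: replacing 2,3-dimethoxyphenyl with 2-hydroxy-5-methoxyphenyl gives a 43-fold lower number from compound 2 to compound 3 (1.63 log units; beyond the scatter), and replacing 3-chlorophenyl with it gives a 53-fold lower number from compound 1 to compound 3 (1.73 log units; beyond the scatter). The earlier swap at this place gave only a 1.3-fold lower number from compound 1 to compound 2 (0.10 log units; within the scatter), so that result did not show that every aryl group here would be tolerated alike. Among these three compounds, the large shift appears only with the group that has a hydrogen-bond donor, which the other two groups lack.

The compounds shown leave open whether the hydroxyl alone accounts for the shift or whether the placement of the methoxy also matters, and a plain hydroxyphenyl or an amine in place of the hydroxyl would help separate these. No supporting measurement is available to explain the result.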